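The source may hold more compounds than are shown below. What is called first, only, known or untested is meant among the compounds shown, and "the series" means these compounds.

Measured so far in a functional assay on the whole organism for inhibition, with Rattus norvegicus as the target; a higher number here means that more compound is needed for the effect, a lower number that less compound is needed:
compound 1 `CC(C)C[C@H](NC(=O)[C@@H]1CCC(=O)N1)C(=O)N1CSC[C@@H]1C(N)=O` gives 31.4 mg/kg
compound 2 `CCC[C@H](NC(=O)[C@@H]1CCC(=O)N1)C(=O)N1CSC[C@@H]1C(N)=O` gives 56 mg/kg

Compound 2 stands level with compound 1, the two being separated only by a 1.8-fold higher number from compound 1 to compound 2 (0.25 log units; within the scatter) and thus not distinguishable. Next comes compound 3 `CCC[C@H](NC(=O)[C@@H]1CCCC(=O)N1)C(=O)N1CSC[C@@H]1C(N)=O`, with this change from compound 2: 6-oxopiperidin-2-yl in place of 5-oxopyrrolidin-2-yl on a carbonyl carbon that is, 6-oxopiperidin-2-yl in place of 5-oxopyrrolidin-2-yl on a carbonyl carbon. Going by the values given here, the one measured step, a 1.8-fold higher number from compound 1 to compound 2 (0.25 log units; within the scatter), lies on a saturated chain carbon and not at this place. Among the compounds with values here, no measured step therefore covers this change, and that step serves only as a rough guide to size in this assay here. No step beyond the scatter is expected, and no direction is favoured, although the uncertainty is wide. The expected step is a 1.1-fold higher number from compound 2 to compound 3 (0.03 log units; within the scatter) on present data. For compound 3 the estimated value is 60 mg/kg, with an expected range from 20 mg/kg to 170 mg/kg on these two measurements.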

Compound 3, dose for half-maximal effect: 60.3 mg/kg
For compound 3 the middle estimate is 1.0-fold (0.00 log units) below the measured one; the measured number falls inside the stated range.
By their numbers in this assay, from the lowest: compounds 1, 2 and 3 (each within the scatter of the next).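

Going by these compounds alone, replacing 5-oxopyrrolidin-2-yl with 6-oxopiperidin-2-yl on a carbonyl carbon gives, in this assay, a 1.1-fold higher number from compound 2 to compound 3 (0.03 log units; within the scatter), the first reading at this place, and the six-membered ring cannot be told apart from the five-membered ring. The earlier step spoke only to a saturated chain carbon, whereas this one shows that the ring on the carbonyl carbon can change size without a readable shift in this assay. Nothing at hand bears on the reason for this result.

Going by these compounds, whether a group of another kind on this carbonyl carbon, such as a carboxylic acid or an amine in place of the ring, would move the number beyond the scatter remains open. Also open, on these data alone, is how 6-oxopiperidin-2-yl behaves with the chain of compound 1.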